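A Bromothiophene Variant of Compound 3

The source may report more compounds than this note shows. Statements on the series, on what has been measured and on what is new or still open speak of the compounds shown alone.

Of the compounds shown here, three have so far been tested in an ADME assay on CCRF-CEM cells (Homo sapiens) for cytotoxicity, with a stated time of 5 days; on this read-out lower numbers stand for stronger inhibition and higher numbers for weaker inhibition. Compound 1 `Cc1csc(C(=O)/C=C/c2ccc(N3CCCCC3)cc2)c1` gives 33300 nM, and compound 2 `Cc1ccc(C(=O)/C=C/c2ccc(N3CCCCC3)cc2)s1` gives 21200 nM. Compound 3 `c1cc(C2=NNC(c3ccc(N4CCCCC4)cc3)C2)cs1` gives 27000 nM, the second highest of the three numbers; its nearest neighbour is compound 1 and its furthest is compound 2, and both of those gaps lie within the scatter. Going by the values given here, the only step between two measured compounds that differ in one place is a 1.6-fold lower number from compound 1 to compound 2 (0.20 log units; within the scatter), which is likewise within the scatter.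

Compound 4 `Brc1ccc(C2=NNC(c3ccc(N4CCCCC4)cc3)C2)s1` is the next compound to be measured. Relative to compound 3 the change is 5-bromothiophen-2-yl in place of thiophen-3-yl on a carbon with a double bond to nitrogen. Among the compounds with values here, none of the measured compounds carries a bromine, and the one measured step, a 1.6-fold lower number from compound 1 to compound 2 (0.20 log units; within the scatter), involved only a shift of a methyl group on a thiophene attached to a carbonyl carbon, not a change on a carbon with a double bond to nitrogen. With no bearing step beyond the scatter, the expectation for compound 4 is a step of no change at the digits printed from compound 3 to compound 4 (within the scatter), that is, no change beyond the scatter. Compound 4 is therefore estimated at 27000 nM, with a range from 9000 nM to 80000 nM.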

Compound 4, half-maximal inhibitory concentration: 21500 nM
For compound 4 the middle estimate is 1.3-fold (0.10 log units) above the measured one; measured number inside the range.
By their numbers in this assay, from the lowest: compounds 2, 4, 3 and 1 (each within the scatter of the next).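

Going by these compounds alone, compound 4 gives the first reading for a change on a carbon with a double bond to nitrogen of the five-membered non-aromatic ring: in this assay, putting 5-bromothiophen-2-yl in place of thiophen-3-yl gives a 1.3-fold lower number from compound 3 to compound 4 (0.10 log units; within the scatter). The earlier step concerned only a methyl group on a thiophene attached to a carbonyl carbon, whereas this one shows that a thiophene carrying a bromine and joined through a different ring carbon can stand at this place without a difference beyond the scatter. No measurement shown here accounts for this result.

Within the data shown here, the single step combines two alterations, the bromine and the switch from thiophen-3-yl to a thiophen-2-yl attachment, so a plain thiophen-2-yl at this place would be needed to read each one alone. From the compounds shown here alone, it also remains open whether a group of a different kind here, such as a carboxylic acid or an amine, would shift the number beyond the scatter, since both groups compared so far are thiophenes.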